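The compounds below may be only part of what the source reports. "The series", "measured", "known", "first", "only" and "open" are said of these compounds alone.

Compound 1, `CC(=O)N(O)C(C)c1ccc(OCCc2ccccc2)cc1`: 410 nM
Compound 2, `CC(=O)N(O)C(C)c1ccc2oc(-c3ccccc3)cc2c1`: 490 nM

Both numbers come from an assay on RBL cells for inhibition of Polyunsaturated fatty acid 5-lipoxygenase (Rattus norvegicus); a higher number here means a weaker inhibitor, a lower number a stronger inhibitor. Compound 2 has the higher of the two numbers, but its nearest neighbour, compound 1, lies within the usual scatter of it, so the two cannot be put in order. For the measured compounds named here, they differ in several places at once and no single step between them is recorded; what the pair shows is only that two different cores carrying the same acetyl(hydroxy)amino side chain reach about the same number in this assay.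

Compound 3, `COCC(=O)N(O)C(C)c1ccc2oc(-c3ccccc3)cc2c1`, keeps the core of compound 2 and differs from it in one place: methoxy in place of hydrogen on a saturated chain carbon bound to a carbonyl carbon. Going by the values given here, no measured pair differs in that way, so there is no precedent in this set for what the change does. Without one, a small step is expected, a 1.2-fold higher number from compound 2 to compound 3 (0.09 log units; within the scatter), most likely within the scatter and leaning, if anywhere, toward a somewhat higher number. Compound 3 is therefore estimated at 600 nM in this assay, with a range from 200 nM to 1800 nM.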

Compound 3, half-maximal inhibitory concentration: 160 nM
Beside the measured number, compound 3's estimate is 3.8-fold (0.57 log units) above it; measured number outside the range, below it.
By their numbers in this assay, from the lowest: compound 3; then compounds 1 and 2 (each within the scatter of the next).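

The saturated chain carbon bound to a carbonyl carbon proves to be a place where a change registers in this assay: methoxy in place of hydrogen there gives a 3.1-fold lower number from compound 2 to compound 3 (0.49 log units; beyond the scatter), a modest step but one beyond the scatter. Acetyl can therefore give way to (methoxymethyl)carbonyl on the core of compound 2 with the number going down rather than up, and this is the first change in the set whose size can be read, since compound 1 and compound 2 differ in several places at once. Nothing measured here accounts for the size or direction of the step.

From the compounds shown here alone, what stays open is whether the step belongs to the oxygen of the methoxy or would also come with a plain carbon chain, as an ethyl group in the same place would show, and whether a hydroxy group or an amine there would behave alike. Going by these compounds, it is also open whether the same change would carry over to the core of compound 1, since the step is known on one core only.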